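The source may report more compounds than this note shows. Statements on the series, on what has been measured and on what is new or still open speak of the compounds shown alone.

Compound 1 `CC(C)N(C(=O)CN1C=CN(c2ccccc2)C(=O)C(Cc2n[nH]c3ccccc23)C1=O)c1ccc(F)cc1` gives 50.1 nM in a functional assay on CHO cells for agonist activity at Melanocyte-stimulating hormone receptor (Homo sapiens), read by a luciferase reporter, with a stated time of 4 h; a lower number here means that less compound is needed, a higher number that more compound is needed for the effect.
Compound 2 `O=C1C(Cc2n[nH]c3ccccc23)C(=O)N(c2ccccc2)C=CN1CC(=O)N1CCCCc2ccccc21` gives 1.59 nM in this assay.
Compound 3 `CC(C)N(C(=O)CN1C=CN(c2ccccc2)C(=O)C(Cc2n[nH]c3cc(F)ccc23)C1=O)c1ccc(F)cc1` gives 14.1 nM in this assay.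

Among these three, compound 1 stands highest, meaning that it needs the most compound for the effect. Compound 3 is nearest to it, and the step between them is a 3.6-fold lower number from compound 1 to compound 3 (0.55 log units; beyond the scatter). Compound 2 is furthest, and the step there is a 32-fold lower number from compound 1 to compound 2 (1.50 log units; beyond the scatter).

Compound 4 `COC1(Cc2n[nH]c3ccccc23)C(=O)N(CC(=O)N(c2ccc(F)cc2)C(C)C)C=CN(c2ccccc2)C1=O` differs from compound 1 in one place: methoxy in place of hydrogen on a saturated ring carbon. Neither measured step bears directly on this change. The step from compound 1 to compound 2 exchanged the group on the carbonyl carbon of the side chain, and the step from compound 1 to compound 3 put fluoro on an aromatic carbon; both changes sit away from the saturated ring carbon of the shared core. The measured steps show only that this series can respond to changes in size, one large and one modest, not what a methoxy at this ring carbon does. Without a direct precedent, the expected step from compound 1 to compound 4 is a 1.2-fold higher number from compound 1 to compound 4 (0.08 log units; within the scatter). Compound 4 is thus estimated at 60 nM in this assay, with a range from 15 nM to 250 nM.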

Compound 4, half-maximal effective concentration: 2950 nM
Beside the measured number, compound 4's estimate is 49-fold (1.69 log units) below it; measured number outside the range, above it.
By their numbers in this assay, from the lowest: compound 2; then compound 3; then compound 1; then compound 4.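

In this assay, methoxy in place of hydrogen on this saturated ring carbon gives a 59-fold higher number from compound 1 to compound 4 (1.77 log units; beyond the scatter). The earlier steps, at the side chain and on an aromatic carbon, both lowered the number, so this ring carbon of the shared core is the first place shown where a change raises it. Even a group as small as methoxy can thus produce a large step here. Nothing available explains this rise.

The compounds shown do not tell whether a methyl, a hydroxyl or a fluoro at this ring carbon would raise the number as much as methoxy does. They also leave open whether methoxy would give a similar step on compound 2, with its different side chain.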